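A few compounds are considered here, and "the series" means these few. Any claim that something is new, unique, unknown or untested is made for them only; others in the source may bear on it.

Measured so far in a physicochemical assay for lipophilicity; on this read-out lower numbers stand for lower lipophilicity and higher numbers for higher lipophilicity:
compound 1 `CC(/C=C/CC(C)CCCC(C)C)=C\C(=O)OC(C)(C)C` — 7.56
compound 2 `C=CCOC(=O)/C=C(C)/C=C/CC(C)CCCC(C)(C)OC` — 5.53
compound 3 `COC(C)(C)CCCC(C)C/C=C/C(C)=C/C(=O)OC1CCC1` — 6.44

Compound 3 stands second highest of the three numbers in this assay; its nearest neighbour is compound 2, and compound 1 is furthest. For the measured compounds named here, the only measured step that touches the group on the carbonyl is a number 0.91 log units higher from compound 2 to compound 3 (beyond the scatter), a modest change for cyclobutyl in place of allyl on an oxygen next to a carbonyl group.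

Compound 4 `CCC(=O)/C=C(C)/C=C/CC(C)CCCC(C)(C)OC` differs from compound 3 as follows: ethyl in place of cyclobutyloxy on a carbonyl carbon. Going by the values given here, no measured step shows ethyl in place of cyclobutyloxy, so the step from compound 2 to compound 3 bears on it only as a sign that changes at this carbonyl move this assay by amounts beyond the scatter. The entering ethyl is smaller than the leaving cyclobutyloxy, so the expected step is downward: a number 0.74 log units lower from compound 3 to compound 4 (beyond the scatter) is the estimated step from compound 3 to compound 4. Compound 4 is accordingly expected to give about 5.7 in this assay, within a range of 5 to 6.4.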

Compound 4, partition coefficient: 5.07
Beside the measured number, compound 4's estimate is 0.63 log units above it; low and high end bracket the measured number.
By their numbers in this assay, from the lowest: compound 4; then compound 2; then compound 3; then compound 1.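

In this assay, ethyl on the carbonyl carbon gives a number 1.37 log units lower from compound 3 to compound 4 (beyond the scatter) and a number 0.46 log units lower from compound 2 to compound 4 (beyond the scatter), so the change is a large step against cyclobutyloxy and a modest one against allyloxy. Both steps run downward, which places the propanoyl member, compound 4, lowest of compound 2, compound 3 and compound 4, and shows that the size of the fall depends on the group that leaves. Nothing available accounts for these steps.

Open, as far as these compounds go, is where a longer chain such as butyl, or an amine, would fall on this carbonyl carbon relative to ethyl and the two oxygen-linked groups. Also open, from the compounds shown here alone, is whether the change to ethyl would give a similar step on the core of compound 1.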